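A Benzylamine Swap on a Shared Core

The source may report more compounds than this note shows. Statements on the series, on what has been measured and on what is new or still open speak of the compounds shown alone.

Measured so far:
compound 1, `C=C1CC[C@@H]2[C@](C)(CO)[C@H](O)CC[C@@]2(C)[C@@H]1CC=O`, > 30000 nM
compound 2, `C=C1CC[C@@H]2[C@](C)(CNCc3cccc(OC)c3)[C@H](O)CC[C@@]2(C)[C@@H]1/C=C/C1=CCOC1=O`, 780 nM

In a functional assay on BMMC cells (Mus musculus, strain C57BL/6) for inhibition, with stated times of 5 days and 48 h (a higher number here means a weaker inhibitor, a lower number a stronger inhibitor), compound 1 reaches only a limit, reported as > 30000 nM; this is the limit of > 30000 nM in this assay, at which 1 of the 2 values shown sits. In this assay, for the measured compounds named here, compound 2 gives 780 nM, the single real number among the two values, so compound 2 stands alone as the reference. Compound 3, `C=C1CC[C@@H]2[C@](C)(CNCc3ccc([N+](=O)[O-])cc3)[C@H](O)CC[C@@]2(C)[C@@H]1/C=C/C1=CCOC1=O`, differs from compound 2 by 4-nitrophenyl in place of 3-methoxyphenyl on a saturated chain carbon bound to an amine nitrogen. Going by the values given here, no pair of measured compounds differs in one place, so nothing shows how such a change moves the value; a shift of roughly the scatter, in either direction, is expected. Compound 3 is expected to give 1000 nM in this assay, between 300 nM and 3500 nM. The estimated step is a 1.3-fold higher number from compound 2 to compound 3 (0.11 log units; within the scatter).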

Compound 3, half-maximal inhibitory concentration: 1340 nM
Estimate against measurement, compound 3: 1.3-fold (0.13 log units) below; the measured number falls inside the stated range.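

In this assay the swap on a saturated chain carbon bound to an amine nitrogen gives a 1.7-fold higher number from compound 2 to compound 3 (0.24 log units; within the scatter). For the compounds shown here, this is the first one-place comparison, and it does not tell 4-nitrophenyl and 3-methoxyphenyl apart at this position. Nothing measured here bears on a cause for this step.

As far as these compounds go, both groups are substituted phenyl rings, so a plain phenyl, a carboxylic acid on the ring or a longer chain to the amine nitrogen remains open. From the compounds shown here alone, whether any group at this position moves the value beyond the scatter also remains open.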